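This account rests on a few compounds, and the source may have more. Where it says the series, first, only, none or still open, it means among the compounds named here.

Compound 1 `COC(=O)c1ccc(NC(=O)C2(C(=O)Nc3ccc(Nc4ncc5cc(C(=O)N(C)C)n(C6CCCC6)c5n4)cc3)CC2)cc1`: 92%
Compound 2 `CN(C)C(=O)c1cc2cnc(Nc3ccc(NC(=O)C4(C(=O)Nc5ccc(Cl)cc5)CC4)cc3)nc2n1C1CCCC1`: 101%
Compound 3 `COc1ccc(NC(=O)C2(C(=O)Nc3ccc(Nc4ncc5cc(C(=O)N(C)C)n(C6CCCC6)c5n4)cc3)CC2)cc1`: not yet measured

In a functional assay on A549 cells (Homo sapiens) for inhibition, read by CCK-8 assay, with a stated time of 72 h, tested at 10 uM (on this read-out higher numbers stand for more inhibition of growth at the one concentration tested and lower numbers for less inhibition of growth), compound 2 gives 101%, level with compound 1 within the scatter. Compound 3 carries methoxy in place of chloro on an aromatic carbon, para to a large group: methoxy in place of chloro on an aromatic carbon. Within the data shown here, the one measured step that bears on this is the exchange at that same aromatic carbon, a number 9 percentage points higher from compound 1 to compound 2 (within the scatter), and it stays small. No step beyond the scatter is therefore expected in this assay. The expected change is a number 6 percentage points lower from compound 2 to compound 3 (within the scatter). Compound 3 is estimated at 95%, within an expected range of 82% to 104%.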

Compound 3, percent growth inhibition at one concentration: 78.5%
For compound 3 the middle estimate is 16.5 percentage points above the measured one, outside the stated range (below it).
By their numbers in this assay, from the lowest: compound 3; then compounds 1 and 2 (each within the scatter of the next).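

In this assay, this aromatic carbon, para to a large group, turns out not to tolerate every exchange: methoxy in place of chloro gives a number 22.5 percentage points lower from compound 2 to compound 3 (beyond the scatter) and methoxy in place of methoxycarbonyl gives a number 13.5 percentage points lower from compound 1 to compound 3 (beyond the scatter). Chloro and methoxycarbonyl had stayed within the scatter of each other, so methoxy is the first group here to separate from the others. No available data explain this drop. Open, as far as these compounds go, is whether the drop is specific to methoxy or extends to other groups at this carbon, such as an amine or a nitrile.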